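A few compounds are considered here, and "the series" means these few. Any claim that something is new, unique, unknown or untested is made for them only; others in the source may bear on it.

Measured so far:
- compound 1, `CC1=C(CO)C(C)(C)C[C@H](O)[C@@H]1O[C@@H]1O[C@H](CO)[C@@H](O)[C@H](O)[C@H]1O`: > 100000 nM
- compound 2, `CC1(C)CC(=O)C=C(C(=O)O)[C@]1(C)O`: > 100000 nM

The study rests on two measured compounds, both characterised in a functional assay on NRK-52E cells (Rattus norvegicus), with stated times of 5 min and 72 h; a higher number here means that more compound is needed for the effect, a lower number that less compound is needed. In this assay compound 1 gives > 100000 nM, which is a limit of the assay rather than a number. In this assay compound 2 likewise gives > 100000 nM, again a limit and not a number. Compound 2 therefore stands nowhere in particular on the numbers shown: it sits at the limit of > 100000 nM in this assay, at which 2 of the 2 values shown sit, with no measured step to any other compound that would place it higher or lower.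

The account now follows the step from compound 2 to compound 3, `CC1(C)CC(=O)C=C(C(=O)O)[C@@]1(C)O`, which has not yet been measured in this assay. The change is small as drawn: the two compounds have the same atoms and bonds and differ only in configuration as drawn: 1 of 1 stereo elements differ; a stereocentre at a saturated ring carbon is drawn R in compound 2 and S in compound 3.

Among the measured compounds shown here, with no measured step available, and with compound 2 at > 100000 nM, the author expects compound 3 to remain at the limit of this assay, with no step beyond the scatter, so that a step that the limit leaves unreadable from compound 2 to compound 3 is estimated to be essentially none. Compound 3 is thus expected to give about 150000 nM, within 50000 nM to 500000 nM.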

Compound 3, half-maximal effective concentration: > 100000 nM
Compound 3: no number, only a limit; the forecaster's own chance of this, stated with the estimate: 85%; the middle value is on the limit's open side.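

In this assay compound 3 gives > 100000 nM, which is a limit of the assay and not a number. Among the compounds shown here, compound 2 also stands at a limit, so no step between compound 2 and compound 3 can be read. The compounds shown leave open whether the configuration at this stereocentre affects the half-maximal effective concentration at all: the limit of > 100000 nM in this assay, at which 3 of the 3 values shown sit.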